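The source may report more compounds than this note shows. Statements on the series, on what has been measured and on what is new or still open speak of the compounds shown alone.

Of the compounds shown here, two have so far been tested in an ADME assay on L1210/0 cells (Mus musculus) for cytotoxicity, with a stated time of 48 h; on this read-out higher numbers stand for weaker inhibition and lower numbers for stronger inhibition. Compound 1, whose structure is `OC[C@@H]1C[C@H](Cn2cnc3c(NC4CC4)ncnc32)c2c(-c3ccccc3)nnc(-c3ccccc3)c21`, reached only the limit of this assay, reported as > 200000 nM. That limit is one of the two results shown, and it appears as the limit of > 200000 nM in this assay, at which 1 of the 2 values shown sits. Compound 2, whose structure is `C=C(Cl)c1cn([C@H]2C[C@H](O)[C@@H](CO)O2)c(=O)[nH]c1=O`, gives 1660 nM in this assay. This is the only definite number among the results shown. Compound 3, with structure `CCCCC#Cc1cn([C@H]2C[C@H](O)[C@@H](CO)O2)c(=O)[nH]c1=O`, has not yet been measured. It differs from compound 2 in one place: hex-1-yn-1-yl in place of 1-chloroethenyl on an aromatic carbon. The hex-1-yn-1-yl group that enters is a longer carbon chain than the 1-chloroethenyl group that leaves, and it carries a triple bond outside aromatic rings where the old group carried a double bond. For the measured compounds named here, no measured pair of compounds shows the effect of such a swap, so the size of the step can only be estimated. The expectation is a step in this assay toward weaker inhibition, beyond the usual scatter, of a 6.0-fold higher number from compound 2 to compound 3 (0.78 log units; beyond the scatter). Compound 3 is therefore estimated at 10000 nM, with a range from 1500 nM to 60000 nM.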

Compound 3, half-maximal inhibitory concentration: > 200000 nM
Compound 3: only a limit was reported; the forecaster's own chance of this, stated with the estimate: 15%; middle value at least 20-fold (1.30 log units) away from the limit.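

At this position, the aromatic carbon two atoms from the ring nitrogen, putting hex-1-yn-1-yl in place of 1-chloroethenyl gives, in this assay, an at least 120-fold higher number from compound 2 to compound 3 (2.08 log units; beyond the scatter). For the compounds shown here, this is the first step that can be read, and it shows that the read-out is far from indifferent to the group at this one place, since the rest of the structure stays the same and a definite value gives way to a limit. Compound 3 yields only a limit and not a number, so the step gives a lower bound on the change and its true size stays unknown, and the result is not alone at that limit: the limit of > 200000 nM in this assay, at which 2 of the 3 values shown sit.

The step changes two things at once, the length of the carbon chain and the triple bond in place of a double bond, and the compounds shown cannot tell which of the two matters or whether both do. Ethynyl, a short group with the triple bond, and hexyl, a chain of the same length without it, would pull these two changes apart at this position.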